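The compounds below may be only part of what the source reports. "The series", "measured", "known", "first", "only" and "open" are said of these compounds alone.

Compound 1 `CN(C)C(=O)c1ccc(-c2cc(C3=CC(=O)C=CC3=O)no2)s1`: in a functional assay on PC-3 cells (Homo sapiens) for cytotoxicity, read by XTT assay, with a stated time of 72 h (a lower number here means a stronger inhibitor, a higher number a weaker inhibitor), compound 1 gives 7200 nM.
Compound 2 `O=C1C=CC(=O)C(c2cc(-c3ccc(C(=O)N4CCC(C(F)(F)F)CC4)s3)on2)=C1`: in this assay compound 2 gives > 30000 nM, which is a limit of the assay rather than a number.

Compound 1 holds the only number shown in this assay; the other value is a limit (the limit of > 30000 nM in this assay, at which 1 of the 2 values shown sits). Compound 3 `COc1ccc(CN(C)C(=O)c2ccc(-c3cc(C4=CC(=O)C=CC4=O)no3)s2)cc1` differs from compound 1 by 4-methoxyphenyl in place of hydrogen on a saturated chain carbon bound to an amide-type nitrogen. Among the measured compounds shown here, the one measured step, also a change at the amide, gave an at least 4.1-fold higher number from compound 1 to compound 2 (0.61 log units; beyond the scatter), a weakening. By that step from compound 1 to compound 2, the estimated step from compound 1 to compound 3 is a 1.7-fold higher number from compound 1 to compound 3 (0.22 log units; within the scatter), expected to weaken. Compound 3 is therefore expected to give 12000 nM, with a range of 4000 nM to 40000 nM.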

Compound 3, half-maximal inhibitory concentration: < 30000 nM
Compound 3: only a limit was reported; the forecaster's own chance of this, stated with the estimate: 30%; the middle value does not contradict the limit.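

In this assay, among the compounds shown here, compound 3 gives < 30000 nM, which is a limit and not a number, so no step from compound 1 to compound 3 can be read. The compounds shown leave open how 4-methoxyphenyl at that place changes the number in this assay.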